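The source may hold more compounds than are shown below. What is called first, only, known or untested is meant among the compounds shown, and "the series" means these compounds.

Values in a functional assay on SW480 cells (Homo sapiens) for antiproliferative activity (on this read-out higher numbers stand for weaker inhibition and lower numbers for stronger inhibition), for the measured members of the series:

compound 1 `COc1ccc(C(Nc2nc(O)c3ncn(C4OC(COC(=O)[C@@H]5OC(C)(C)N(C(=O)c6ccccc6)[C@H]5c5ccccc5)C5OC(C)(C)OC54)c3n2)(c2ccccc2)c2ccccc2)cc1`: 152000 nM
compound 2 `COc1ccc(C(Nc2nc(O)c3ncn(C4OC(COC(=O)[C@@H]5OC(C)(C)N(C(C)=O)[C@H]5c5ccccc5)C5OC(C)(C)OC54)c3n2)(c2ccccc2)c2ccccc2)cc1`: 19900 nM
compound 3 `CC(C)C(=O)Nc1nc(O)c2ncn(C3OC(COC(=O)[C@@H]4OC(C)(C)N(C(=O)c5ccccc5)[C@H]4c4ccccc4)C4OC(C)(C)OC43)c2n1`: 222000 nM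

Compound 3 carries the highest number of the three. The nearest is compound 1, whose value sits within the scatter of compound 3, so no order between these two can be read from the data. The furthest is compound 2, which lies beyond the scatter from compound 3.

Compound 4 `CC(=O)N1[C@@H](c2ccccc2)[C@H](C(=O)OCC2OC(n3cnc4c(O)nc(NC(=O)C(C)C)nc43)C3OC(C)(C)OC23)OC1(C)C` is the next member, not yet measured. It differs from compound 3 only in this: methyl in place of phenyl on a carbonyl carbon

Within the data shown here, one measured step bears directly on this change. It is the same replacement, methyl in place of phenyl on a carbonyl carbon, made on a pair that differs from the new pair elsewhere on the shared core. That step reads: a 7.6-fold lower number from compound 1 to compound 2 (0.88 log units; beyond the scatter). It was clearly beyond the scatter and went towards a lower number. Among the measured compounds shown here, no other measured pair informs the change. The expectation for compound 4 is therefore a step of comparable size in the same direction, a lower number than compound 3, as expressed by a 7.7-fold lower number from compound 3 to compound 4 (0.88 log units; beyond the scatter). The estimated value for compound 4 is 29000 nM, with an expected range from 12000 nM to 80000 nM.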

Compound 4, half-maximal inhibitory concentration: 192000 nM
The estimate for compound 4 lay 6.6-fold (0.82 log units) below the measured number, outside the stated range (above it).
By their numbers in this assay, from the lowest: compound 2; then compounds 1, 4 and 3 (each within the scatter of the next).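

In this assay, the benzoyl to acetyl change on the core of compound 3 gives a 1.2-fold lower number from compound 3 to compound 4 (0.06 log units; within the scatter), so on this core the swap leaves no readable difference. The same replacement at this position, on a carbonyl carbon bound to the ring amide-type nitrogen, therefore has no single size across the series, and its outcome differs with the rest of the core: the same change on two cores in this assay, a 7.6-fold lower number (0.88 log units; beyond the scatter) from compound 1 to compound 2 and a 1.2-fold lower number (0.06 log units; within the scatter) from compound 3 to compound 4, 6.6-fold (0.82 log units) apart, beyond the scatter of two such steps. The lower number seen with acetyl holds so far only on the core of compound 1, where compound 2 gives 19900 nM, and compound 4 goes against any wider reading of it.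

With only two cores, the compounds shown do not tell which feature of the shared core separates the two outcomes, or whether the gap would recur on a third core. Going by these compounds, it also stays open whether a propanoyl group, a longer acyl chain or an aminoacetyl group at this position would shift the number on the core of compound 3, or whether this core stays flat at this position whatever the group.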